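Removing One Chloro Group from Compound 1

A few compounds are considered here, and "the series" means these few. Any claim that something is new, unique, unknown or untested is made for them only; others in the source may bear on it.

- Compound 1 `COc1cc(CNCc2ccncc2)ccc1OCc1ccc(Cl)c(Cl)c1` gives 4000 nM here
- Compound 2 `COc1cc(OCc2ccc(Cl)cc2)ccc1CNCc1ccncc1` gives 440 nM here
- Compound 3 `COc1cc(CNCc2cccnc2)ccc1OCc1ccc(Cl)nc1` gives 5000 nM here

These three numbers come from a functional assay on HeLa cells (Homo sapiens) for inhibition, with a stated time of 72 h (a lower number here means that less compound is needed, a higher number that more compound is needed for the effect), which is how the compounds are compared throughout. Compound 1 lies within the usual scatter of compound 3, so the two cannot be told apart. Compound 2 needs clearly less compound than either, and this gap lies beyond the scatter.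

The next compound to consider is compound 4 `COc1cc(CNCc2ccncc2)ccc1OCc1ccc(Cl)cc1`. It keeps the core of compound 1 but has hydrogen in place of chloro on an aromatic carbon, turning 3,4-dichlorophenyl into 4-chlorophenyl (hydrogen in place of chloro on an aromatic carbon).

For the measured compounds named here, no measured pair shows this change alone, so the data give no direct size for it. In this assay a modest step toward a lower number seems most likely, though one within the scatter is quite possible. The value of compound 2 (440 nM) shows only that much lower numbers occur among these compounds. The expected move is a 1.6-fold lower number from compound 1 to compound 4 (0.20 log units; within the scatter) in this assay. Compound 4 is estimated at 2500 nM (range 800 nM to 7000 nM).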

Compound 4, half-maximal effective concentration: 890 nM
Compound 4: middle estimate off by 2.8-fold (0.45 log units), on the high side; the measured number falls inside the stated range.
By their numbers in this assay, from the lowest: compound 2; then compound 4; then compounds 1 and 3 (each within the scatter of the next).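

In this assay, replacing one chloro group with hydrogen, which turns 3,4-dichlorophenyl into 4-chlorophenyl, gives a 4.5-fold lower number from compound 1 to compound 4 (0.65 log units; beyond the scatter) and so provides the first direct size for a change at this position. The earlier compounds shown here could not show this, as none of them formed a pair differing in one place. The step shows that this aromatic carbon, ortho to a chloro group, matters here: with hydrogen on it, clearly less compound is needed, though no measurement shown accounts for the step.

As far as these compounds go, whether a fluoro, methyl or methoxy group on this carbon would behave more like hydrogen or more like chloro remains open. From the compounds shown here alone, the step has also been read only once, on the core of compound 1, so its size on any other core is unknown.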